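Carbamate ureas: butoxy in place of benzyl

This account rests on a few compounds, and the source may have more. Where it says the series, first, only, none or still open, it means among the compounds named here.

Compound 2 `Nc1nn(C(=O)Nc2ccc(Cc3ccccc3)cc2)c2ccccc12` is the reference point of this set. In a functional assay on HOP-62 cells (Homo sapiens) for inhibition, read by sulforhodamine B assay, with a stated time of 48 h (on this read-out higher numbers stand for weaker inhibition of growth and lower numbers for stronger inhibition of growth), compound 2 gives 13700 nM, the lowest of the two numbers shown. Compound 1 `O=C(Nc1ccc(Cc2ccccc2)cc1)Nc1nn(C(=O)Nc2ccc(Cc3ccccc3)cc2)c2ccccc12` carries a second aryl urea on the shared core, and in this assay compound 1 gives 59700 nM, a higher number than compound 2 and beyond the scatter. Compound 3 `COc1ccc(NC(=O)Nc2n[nH]c3ccccc23)cc1` is recorded only as a limit in this assay, where compound 3 gives > 100000 nM (the limit of > 100000 nM in this assay, at which 1 of the 3 values shown sits). Compound 4 `CCCCOc1ccc(NC(=O)n2nc(N)c3ccccc32)cc1` differs from compound 2 by butoxy in place of benzyl on an aromatic carbon. For the measured compounds named here, no measured step covers this exchange; a small shift toward a higher number, not clearly beyond the scatter, is expected. Compound 4 is estimated at 25000 nM, within 8000 nM to 90000 nM. The expected step is a 1.8-fold higher number from compound 2 to compound 4 (0.26 log units; within the scatter).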

Compound 4, concentration for 50% growth inhibition: 20800 nM
For compound 4 the middle estimate is 1.2-fold (0.08 log units) above the measured one; the range from low to high includes it.
By their numbers in this assay, from the lowest: compounds 2 and 4 (each within the scatter of the next); then compound 1. At a limit, above all of these: compound 3.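

Butoxy in place of benzyl on this aromatic carbon, para to a large group, gives a 1.5-fold higher number from compound 2 to compound 4 (0.18 log units; within the scatter) in this assay. At this position, therefore, the six-membered aromatic ring of benzyl can give way to an open chain with no ring and an added oxygen, without a change beyond the scatter. No measured evidence shown here bears on this step.

From the compounds shown here alone, whether an amine, a carboxylic acid or a longer alkoxy chain on this carbon would keep the number level with compound 2 remains open. Going by these compounds, whether the step holds in other cell lines also remains open.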